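The compounds below may be only part of what the source reports. "The series", "measured", "known", "first", "only" and "open" are said of these compounds alone.

Among the measured compounds shown here, compound 3 `O=c1c(C(=S)Nc2ccccc2)coc2ccccc12` is the one compound whose result in a functional assay on COLO 205 cells (Homo sapiens) for inhibition, read by sulforhodamine B assay, with a stated time of 48 h (a higher number here means a weaker inhibitor, a lower number a stronger inhibitor), is an actual number: in this assay compound 3 gives 72600 nM. Compound 1 `O=c1c(C(=S)Nc2ccccc2)coc2cc(Cl)ccc12`, which carries a chloro group on the shared core, returns only a limit of the assay: in this assay compound 1 gives > 100000 nM. Compound 2 `O=c1c(C2N=C(c3ccccc3)SS2)coc2ccc(F)cc12`, built with a different side group on a fluoro-bearing core, likewise reaches only a limit: in this assay compound 2 gives > 100000 nM. For the measured compounds named here, the single step between measured compounds, an at least 1.3-fold lower number from compound 1 to compound 3 (0.13 log units; that floor lies within the scatter), sits at the floor set by the limit of > 100000 nM in this assay, at which 2 of the 3 values shown sit, so it points to no change beyond the scatter in either direction.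

Compound 4 `O=c1c(C(=S)Nc2ccccc2)coc2ccc(F)cc12` is compound 3 with fluoro in place of hydrogen on an aromatic carbon. A small halogen thus enters the same six-membered aromatic ring of carbon only on which the chloro of compound 1 met a limit. The expected step is a 1.4-fold higher number from compound 3 to compound 4 (0.14 log units; within the scatter), and a limit is quite possible. The estimate for compound 4 in this assay is 100000 nM, with a range from 30000 nM to 300000 nM.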

Compound 4, half-maximal inhibitory concentration: > 100000 nM
Compound 4 ended at the assay's limit; the forecaster's own chance of this, stated with the estimate: 50%; the middle value sits exactly at the limit.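

The step is an at least 1.3-fold higher number from compound 3 to compound 4 (0.13 log units; that floor lies within the scatter), and because it rests on a limit it is only a floor: fluoro in place of hydrogen on this aromatic carbon shows no change beyond the scatter, and the true size of the step stays hidden. What is new is a direct test of this position with the side group of compound 3 in place, and it gives no number, just as compound 2, which has fluoro at the same position with a different side group, gave none. A limit is all that can be read here, and it is now the most common result in the set: the limit of > 100000 nM in this assay, at which 3 of the 4 values shown sit.

On these data alone, how far compound 4 lies past the limit remains open. So does whether a methoxy group or an amine on this same aromatic carbon would give a real number.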